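The compounds below may be only part of what the source reports. "The series", "measured", "known", "first", "only" and "open" are said of these compounds alone.

Working notes on the series.

Compound 1 `CC(C)S(=O)(=O)NC(=O)c1ccc(Nc2nc(NC3(c4ccc(Cl)cc4)CC3)nc(OCC(F)(F)F)n2)cc1` gives 96% in an ADME assay on microsomes from liver (Rattus norvegicus) for metabolic stability, with a stated time of 10 min (a higher number here means that more of the compound is left, a lower number that less of the compound is left), and stands highest of the two numbers recorded there. Its nearest neighbour is compound 3 `O=C(NS(=O)(=O)C1CC1)c1ccc(Nc2nc(NC3(c4ccc(Cl)cc4)CC3)nc(OCC(F)(F)F)n2)cc1`, which in this assay gives 85%; the change of cyclopropyl in place of isopropyl on the sulfonyl sulfur reads a number 11 percentage points lower from compound 1 to compound 3 (beyond the scatter). Going by the values given here, compound 2 `O=C(NS(=O)(=O)CCNC(=O)C1CC1)c1ccc(Nc2nc(NC3(c4ccc(Cl)cc4)CC3)nc(OCC(F)(F)F)n2)cc1` is reported in this assay only as "not active" (no number reported), without a number, and gives no step to compare.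

Compound 4 `CS(=O)(=O)NC(=O)c1ccc(Nc2nc(NC3(c4ccc(Cl)cc4)CC3)nc(OCC(F)(F)F)n2)cc1` is not yet measured. It differs from compound 1 by methyl in place of isopropyl on a sulfonyl sulfur. Among the compounds with values here, the only measured step at the same place is the one from compound 1 to compound 3, and it was modest. A step of similar size or smaller is therefore expected in this assay, downward if at all, possibly within the scatter. The estimate for compound 4 in this assay is 90%, with a range from 75% to 100%. The step from compound 1 to compound 4 is expected to read a number 6 percentage points lower from compound 1 to compound 4 (within the scatter), because compound 3 showed a number 11 percentage points lower from compound 1 to compound 3 (beyond the scatter) for a change at the same position.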

Compound 4, percent of the compound remaining: 85%
Estimate against measurement, compound 4: 5 percentage points above, and the stated range covers the measured number.
By their numbers in this assay, from the lowest: compounds 3 and 4 (each within the scatter of the next); then compound 1.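

Methyl in place of isopropyl on the sulfonyl sulfur gives a number 11 percentage points lower from compound 1 to compound 4 (beyond the scatter) in this assay so both replacements of isopropyl shown at this place now read beyond the scatter, where earlier only the cyclopropyl one could be read. Methyl in place of cyclopropyl gives no change at the digits printed from compound 3 to compound 4 (within the scatter) so this assay does not separate these two groups, while compound 1 with its isopropyl keeps the highest number among the three compounds with a number. No measurement at hand accounts for these steps.

Open, as far as these compounds go, is how a phenyl ring, a longer chain such as butyl or a chain ending in an amine or a carboxylic acid would read on the sulfonyl sulfur. Also open, from the compounds shown here alone, is whether the steps seen at this place would hold with a different group elsewhere on the shared core.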